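From ethoxy to thiophen-2-yl on a carbonyl carbon

The source may hold more compounds than are shown below. What is called first, only, known or untested is meant among the compounds shown, and "the series" means these compounds.

- Compound 1 `Nc1nn(C(=O)c2ccc([N+](=O)[O-])cc2)c(N)c1/N=N/c1ccc(O)cc1` gives > 25000 nM as a limit
- Compound 2 `CCOC(=O)n1nc(N)c(/N=N/c2ccc(O)cc2)c1N` gives > 100000 nM as a limit

In a functional assay on K562 cells (Homo sapiens) for cytotoxicity, read by fluorescence, with a stated time of 72 h (a lower number here means a stronger inhibitor, a higher number a weaker inhibitor), compound 2 stands at > 100000 nM as a limit and not a number. Compound 1 gives > 25000 nM in this assay and this too is a limit. Neither compound therefore has a measured number.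

Compound 3 `Nc1nn(C(=O)c2cccs2)c(N)c1/N=N/c1ccc(O)cc1` takes thiophen-2-yl in place of ethoxy on a carbonyl carbon and otherwise keeps the structure of compound 2. Within the data shown here, the one measured step that bears on this is a step that the two limits leave unreadable from compound 1 to compound 2 with ethoxy in place of 4-nitrophenyl at that same place. That step offers no size to carry over. Compound 3 resembles compound 1 in holding a ring on the carbonyl carbon, so a result close to the limit of compound 1 (> 25000 nM) is expected, quite possibly again as a limit alone. The expected change is small and toward stronger inhibition, estimated as an at least 2.5-fold lower number from compound 2 to compound 3 (0.39 log units; beyond the scatter) with wide uncertainty. For compound 3 the estimated value is 40000 nM with a range of 10000 nM to 100000 nM expected.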

Compound 3, half-maximal inhibitory concentration: > 25000 nM
Compound 3 was reported as a limit; the forecaster's own chance of this, stated with the estimate: 70%; the middle value does not contradict the limit.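

In this assay, compound 3 gives > 25000 nM, a limit and not a number. Among these compounds, with compound 1 and compound 2 also reported only as limits, no step among the three compounds can be read. The compounds shown leave open whether ethoxy, 4-nitrophenyl or thiophen-2-yl on the carbonyl carbon makes any difference to the read-out.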